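Swapping the side chain of compound 2 for a ring

This account rests on a few compounds, and the source may have more. Where it says the series, first, only, none or still open, it means among the compounds named here.

Compound 1 `COc1ccc(/C=C\c2cc(OC)c(OC)c(OC)c2)cc1OCc1ccc(CNCCO)cc1` reads > 50000 nM as a limit
Compound 2 `COc1ccc(/C=C\c2cc(OC)c(OC)c(OC)c2)cc1OCc1ccc(CNCCNC(C)=O)cc1` reads > 50000 nM as a limit

Both readings come from an ADME assay on HEK293 cells (Homo sapiens) for cytotoxicity, read by CCK-8 assay, with a stated time of 48 h (on this read-out lower numbers stand for stronger inhibition and higher numbers for weaker inhibition), and neither is an exact number. Compound 2 stands at > 50000 nM and this is a limit, so its true value is not known.

Compound 3 `COc1ccc(/C=C\c2cc(OC)c(OC)c(OC)c2)cc1OCc1ccc(CN2CC[C@@H](O)C2)cc1` has not yet been measured. Its difference from compound 2 is 3-hydroxypyrrolidin-1-yl in place of (2-acetamidoethyl)amino on a saturated chain carbon bound to an aromatic carbon and the new ring is attached through the same saturated chain carbon bound to an aromatic carbon.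

Going by the values given here, only one measured step can serve as a guide, a step that the two limits leave unreadable from compound 1 to compound 2 and it has no readable size. Given the limit of > 50000 nM in this assay, at which 2 of the 2 values shown sit, there is no measured size to carry over to this change. No step beyond the usual scatter can therefore be forecast in this assay and no direction can be expected either.

The expected step is a number no higher from compound 2 to compound 3 (the limit leaves the size open) and it remains a rough estimate. For compound 3 the estimated value is 50000 nM with an expected range from 20000 nM to 120000 nM and a reading that is again only a limit is likely.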

Compound 3, half-maximal inhibitory concentration: > 50000 nM
Compound 3: a limit, no number; the forecaster's own chance of this, stated with the estimate: 75%; the middle value lies on the limit itself.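

No step can be read among compound 1, compound 2 and compound 3, because each gives only a limit in this assay: the limit of > 50000 nM in this assay, at which 3 of the 3 values shown sit.

The compounds shown leave open how far apart their true values lie, and whether any of these side chains on the shared core would give an exact number in this assay.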